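Trimethoxybenzohydrazones: from trifluoromethyl to fluoro

The compounds below may be only part of what the source reports. "The series", "measured", "known", "first", "only" and "open" are said of these compounds alone.

Two trimethoxybenzoyl hydrazones have so far been tested in a functional assay on BGC-823 cells (Homo sapiens) for antiproliferative activity, read by MTT assay, tested at 1 uM; on this read-out lower numbers stand for a weaker effect and higher numbers for a stronger effect at the one concentration tested. Compound 1 `COc1cc(C(=O)N/N=C/c2ccc(F)c(F)c2)cc(OC)c1OC` gives 33.1% there. Compound 2 `COc1cc(C(=O)N/N=C/c2ccc(C(F)(F)F)cc2)cc(OC)c1OC` stands highest of the two numbers in this assay, with 47.4%; its nearest neighbour is compound 1, whose value lies lower by more than the usual scatter of repeated measurements of this kind.

The next compound, compound 3 `COc1cc(C(=O)N/N=C/c2ccc(F)cc2)cc(OC)c1OC`, has not yet been measured. It differs from compound 2 in one place: fluoro in place of trifluoromethyl on an aromatic carbon. The group that leaves is much larger than the one that enters, on an aromatic carbon of a six-membered aromatic ring of carbon only, para to a large group.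

Within the data shown here, no step between two measured compounds isolates this change, so the expected direction of the step in this assay is uncertain; the estimate leans to a modest decrease, a number 11.4 percentage points lower from compound 2 to compound 3 (beyond the scatter), a step near the edge of the scatter. Compound 3 is therefore expected to give about 36%, within a range from 18% to 54%.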

Compound 3, a percentage reported as inhibition, at one concentration (the size of the read-out at that concentration, not a potency): 50.9%
Compound 3: middle estimate off by 14.9 percentage points, on the low side, within the range that was stated.
By their numbers in this assay, from the lowest: compound 1; then compounds 2 and 3 (each within the scatter of the next).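

Exchanging trifluoromethyl for fluoro on this aromatic carbon para to a large group gives a number 3.5 percentage points higher from compound 2 to compound 3 (within the scatter) in this assay and so does not separate the two groups, although the one that leaves is much the larger. The step of a number 17.8 percentage points higher from compound 1 to compound 3 (beyond the scatter) in the same assay shows that a change elsewhere on this ring can move the read-out beyond the scatter, as hydrogen replaces the second fluoro of compound 1 while the fluoro para to a large group stays in place. No measurement available here accounts for either step.

As far as these compounds go, whether this place accepts groups of a quite different kind, such as an amine or a carboxylic acid, stays open. So does whether hydrogen at this place would give a read-out like that of compound 2 and compound 3.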